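Inverting one ring stereocentre on a sulfonamide chain

The source may hold more compounds than are shown below. What is called first, only, known or untested is meant among the compounds shown, and "the series" means these compounds.

Three compounds were measured in a physicochemical assay for lipophilicity, read by HPLC, measured as octanol-water partition, at pH 7.4; a higher number here means a more lipophilic compound, a lower number a more polar compound: compound 1 `CC1(C)C[C@@H](CN([C@H](CCC(F)(F)F)C(N)=O)S(=O)(=O)c2ccc(Cl)cc2)O1` gives 3.8, compound 2 `NC(=O)[C@@H](CCC(F)(F)F)N(C[C@H]1CCCCO1)S(=O)(=O)c1ccc(Cl)cc1` gives 4.3, and compound 3 `NC(=O)[C@@H](CCC(F)(F)F)N(C[C@H]1CCCO1)S(=O)(=O)c1ccc(Cl)cc1` gives 3.6. Compound 3 sits near compound 1, the step of a number 0.20 log units lower from compound 1 to compound 3 (within the scatter) being within the scatter, while the step of a number 0.70 log units lower from compound 2 to compound 3 (beyond the scatter) and the step of a number 0.50 log units higher from compound 1 to compound 2 (beyond the scatter) show how swapping one ring for another moves this assay by modest amounts. Compound 4 `NC(=O)[C@@H](CCC(F)(F)F)N(C[C@@H]1CCCO1)S(=O)(=O)c1ccc(Cl)cc1` differs from compound 3 in one way: the two compounds have the same atoms and bonds and differ only in configuration as drawn: 1 of 2 stereo elements differ; a stereocentre at a saturated ring carbon is drawn R in compound 3 and S in compound 4. For the measured compounds named here, none of the measured steps involves such a change of configuration alone, so no measured step bears directly on it. The expectation is therefore a step of no change at the digits printed from compound 3 to compound 4 (within the scatter), not beyond the scatter. Compound 4 is estimated at 3.6, within a range from 3.3 to 3.9.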

Compound 4, distribution coefficient: 3.5
The estimate for compound 4 lay 0.10 log units above the measured number, and the stated range covers the measured number.
By their numbers in this assay, from the lowest: compounds 4, 3 and 1 (each within the scatter of the next); then compound 2.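

In this assay, inverting this saturated ring carbon from R to S gives a number 0.10 log units lower from compound 3 to compound 4 (within the scatter) and so, at this position, configuration alone stays inside the usual noise. Against the other rings, the S form reads a number 0.80 log units lower from compound 2 to compound 4 (beyond the scatter) and a number 0.30 log units lower from compound 1 to compound 4 (within the scatter) so the oxolan-2-yl ring keeps its standing whichever way it is drawn. This pair isolates configuration cleanly, and the reading rests on one point: the fact that compounds 3 and 4 differ only in the configuration as drawn.

On these data alone, whether the same inversion is as silent on the oxan-2-yl ring stays open. So does the outcome for an oxolan-2-yl ring carrying an amine or a carboxylic acid.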